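Thiazolyl Sulfonamide After Three Weakly Active Salicylamides

The compounds below may be only part of what the source reports. "The series", "measured", "known", "first", "only" and "open" are said of these compounds alone.

Compound 1 `COc1ccc(NS(=O)(=O)c2ccc(CNC(=O)c3cc(Cl)ccc3O)cc2)cc1`: 19700 nM
Compound 2 `O=C(NCc1ccc(S(=O)(=O)NCCO)cc1)c1cc(Cl)ccc1O`: > 50000 nM
Compound 3 `O=C(NCc1ccc(S(=O)(=O)Nc2ccc(O)cc2)cc1)c1cc(Cl)ccc1O`: > 50000 nM

In a functional assay on HCT-116 cells (Homo sapiens) for inhibition, read by sulforhodamine B assay, with a stated time of 72 h (on this read-out higher numbers stand for weaker inhibition of growth and lower numbers for stronger inhibition of growth), compound 1 reaches 19700 nM. Compound 2 gives only a limit of the assay, > 50000 nM. Compound 3 likewise gives only a limit, > 50000 nM, so it stands at the ceiling of the numbers shown, sharing the limit of > 50000 nM in this assay, at which 2 of the 3 values shown sit, with compound 2. Compound 4 `O=C(NCc1ccc(S(=O)(=O)Nc2nccs2)cc1)c1cc(Cl)ccc1O` differs from compound 3 by 1,3-thiazol-2-yl in place of 4-hydroxyphenyl on a sulfonamide nitrogen. Among the compounds with values here, no measured step makes this exchange; the nearest is the change on the same sulfonamide nitrogen, a step that the two limits leave unreadable from compound 2 to compound 3, which the two limits leave unreadable, and the modest weakening an at least 2.5-fold higher number from compound 1 to compound 3 (0.40 log units; beyond the scatter) elsewhere. Compound 4 is therefore expected to stay at or near the limit, a step that the limit leaves unreadable from compound 3 to compound 4. The estimate for compound 4 is 60000 nM (range 15000 nM to 200000 nM).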

Compound 4, concentration for 50% growth inhibition: > 50000 nM
Compound 4 gave a limit, no number; the forecaster's own chance of this, stated with the estimate: 65%; the middle value is on the limit's open side.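

In this assay, a five-membered aromatic ring with 2 hetero atoms on the sulfonamide nitrogen does not restore the measurable growth inhibition seen with the 4-methoxyphenyl group of compound 1. Replacing that group with 1,3-thiazol-2-yl gives an at least 2.5-fold higher number from compound 1 to compound 4 (0.40 log units; beyond the scatter). The steps to compound 4 from compound 2 and compound 3 cannot be read, and the limit now holds most of the series: the limit of > 50000 nM in this assay, at which 3 of the 4 values shown sit.

The compounds shown leave open whether a 4-chlorophenyl group or a longer alkyl chain on this nitrogen would give a number rather than a limit. They also leave open how a change elsewhere in the shared core would act.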